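The compounds below may be only part of what the source reports. "The series", "measured", "known", "first", "only" and "open" are said of these compounds alone.

Of the compounds shown here, two have been tested in an assay on isolated protein for inhibition of histone acetyltransferase p300 (Homo sapiens), with a stated time of 60 min; on this read-out lower numbers stand for stronger inhibition and higher numbers for weaker inhibition. Compound 1 `COc1ccc(NC(=O)[C@H]2CCCN2C(=O)C2(c3cccc(Cl)c3)CCCC2)nc1` gives 2 nM in this assay. Among the compounds with values here, compound 2 `CNC(=O)c1cccc(NC(=O)[C@H]2CCCN2C(=O)C2(c3cccc(Cl)c3)CCCC2)c1` gives 1260 nM in this assay, and it stands as the higher of the two numbers, that is, the weaker inhibitor; the only measured step, a 630-fold higher number from compound 1 to compound 2 (2.80 log units; beyond the scatter), separates it from compound 1 and lies well beyond the scatter.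

Compound 3 `CNC(=O)c1ccc(NC(=O)[C@H]2CCCN2C(=O)C2(c3cccc(Cl)c3)CCCC2)cc1` has not yet been measured. It differs from compound 2 in one place: 4-(methylcarbamoyl)phenyl in place of 3-(methylcarbamoyl)phenyl on an amide-type nitrogen. The two compounds share every atom and differ only in how the methylcarbamoyl group is joined to the phenyl ring.

Within the data shown here, no measured step bears directly on this change. The step from compound 1 to compound 2 exchanges a whole ring for another and says nothing about moving a group around the phenyl ring. With no guide in either direction, the number for compound 3 is expected to stay close to that of compound 2, with the step of a 1.3-fold higher number from compound 2 to compound 3 (0.10 log units; within the scatter) estimated to fall within the scatter, though a wide range is kept. Compound 3 is therefore estimated at 1600 nM in this assay, within a range from 300 nM to 8000 nM.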

Compound 3, half-maximal inhibitory concentration: 0.794 nM
Compound 3: the middle estimate sits 2000-fold (3.30 log units) above what was measured; measured number outside the range, below it.
By their numbers in this assay, from the lowest: compound 3; then compound 1; then compound 2.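

Rearranging the same atoms is enough to change the result in this assay: moving the methylcarbamoyl group gives a 1600-fold lower number from compound 2 to compound 3 (3.20 log units; beyond the scatter). At this place on the amide-type nitrogen, how the group is joined to the phenyl ring therefore matters greatly, which the earlier step, an exchange of one whole ring for another, could not reveal. The 5-methoxypyridin-2-yl group of compound 1 is also not needed for a low number, since 4-(methylcarbamoyl)phenyl gives a 2.5-fold lower number from compound 1 to compound 3 (0.40 log units; beyond the scatter), so the high number of compound 2 does not apply to every phenyl ring carrying a methylcarbamoyl group, and no measurement here explains why the arrangement has so large an effect.

As far as these compounds go, it remains open whether the methylcarbamoyl group itself is important in the arrangement of compound 3, or whether a carboxylic acid, a nitrile or a carbamoyl group with a longer chain than methyl would read the same in this assay. Also open, from the compounds shown here alone, is whether moving the methoxy group around the pyridine ring of compound 1 would shift the number as sharply.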